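The source may report more compounds than this note shows. Statements on the series, on what has been measured and on what is new or still open speak of the compounds shown alone.

Measured so far:
- compound 1 `COC(=O)C[C@H]1C[C@@H](O)[C@@H](C)[C@@H](c2ccc(C(C)C)cc2)N1`: "not active" (no number reported)
- compound 2 `COC(=O)C[C@H]1C[C@H](O)[C@@H](C)[C@@H](c2ccc(C(C)C)cc2)N1`: 17100 nM
- compound 3 `COC(=O)C[C@H]1C[C@@H](O)[C@@H](C)[C@@H](c2ccc(OC)cc2)N1`: 10400 nM

Among the compounds with values here, in a functional assay on MCF7 cells (Homo sapiens) for cytotoxicity, read by MTT assay (on this read-out higher numbers stand for weaker inhibition and lower numbers for stronger inhibition), only two compounds have numbers: compound 2 at 17100 nM and compound 3 at 10400 nM. These two lie within the scatter of each other. Compound 1 is reported as "not active" (no number reported), without a number. The contrast with compound 2 comes with the fact that compounds 1 and 2 differ only in the configuration as drawn.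

Next in the series is compound 4 `COC(=O)C[C@H]1C[C@H](O)[C@@H](C)[C@@H](c2ccc(F)cc2)N1`, which has the configuration drawn for compound 2 but carries fluoro in place of isopropyl on an aromatic carbon, para to a large group: fluoro in place of isopropyl on an aromatic carbon. Within the data shown here, no measured pair isolates this change, so the expectation in this assay is for no shift beyond the scatter. It rests on compound 2 at 17100 nM and on compound 3, which bears methoxy on its aromatic ring, at 10400 nM. A report without a number remains possible, as with compound 1 at "not active" (no number reported).

The expected change is a 1.2-fold higher number from compound 2 to compound 4 (0.07 log units; within the scatter), a step not beyond the scatter. For compound 4 the estimated value is 20000 nM, with an expected range of 8000 nM to 50000 nM.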

Compound 4, half-maximal inhibitory concentration: 18200 nM
Beside the measured number, compound 4's estimate is 1.1-fold (0.04 log units) above it, and the stated range covers the measured number.
By their numbers in this assay, from the lowest: compounds 3, 2 and 4 (each within the scatter of the next).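

In this assay the series now has its first measured pair that isolates a change on the aromatic ring, para to a large group: fluoro in place of isopropyl gives a 1.1-fold higher number from compound 2 to compound 4 (0.03 log units; within the scatter). With the configuration drawn for compound 2 held fixed, going from a group of 3 heavy atoms to one of 1 heavy atom leaves the read-out within the scatter, so at this place and in this configuration the size of the substituent, as counted in heavy atoms, does not separate these two compounds. No measured property at hand bears on this step.

Open, on these data alone, is whether the same flat response would hold at this place for an amine, a carboxylic acid or a longer chain, since only the fluoro and isopropyl pair speaks to it in this configuration. Also open, as far as these compounds go, is how fluoro would read in the configuration shared by compound 1 and compound 3, where the two reports differ in kind, one without a number and one with a number.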